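The source may report more compounds than this note shows. Statements on the series, on what has been measured and on what is new or still open speak of the compounds shown alone.

In an ADME assay on MT4 cells (Homo sapiens) for cytotoxicity (on this read-out higher numbers stand for lower toxicity in this test and lower numbers for higher toxicity in this test), compound 1 `FC(F)(F)c1cccc(NC(=S)Nc2ccccc2)c1` gives 39000 nM and compound 3 `Fc1ccc(NC(=S)Nc2cccc(C(F)(F)F)c2)cc1` gives 31000 nM. These two numbers lie within the scatter of each other, as a 1.3-fold lower number from compound 1 to compound 3 (0.10 log units; within the scatter) shows. For the measured compounds named here, compound 2 `CCNC(=S)Nc1cccc(C(F)(F)F)c1` gives > 100000 nM, which is a limit of the assay, and the limit of > 100000 nM in this assay, at which 1 of the 3 values shown sits, is the only such value so far. Compound 4 `C=C(C)CNC(=S)Nc1cccc(C(F)(F)F)c1` carries 2-methylprop-2-en-1-yl in place of 4-fluorophenyl on an amide-type nitrogen.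

Going by the values given here, two measured steps bear on this change, both involving the ethyl of compound 2. Ethyl in place of phenyl gave an at least 2.5-fold higher number from compound 1 to compound 2 (0.40 log units; beyond the scatter), and 4-fluorophenyl in place of ethyl gave an at least 3.2-fold lower number from compound 2 to compound 3 (0.50 log units; beyond the scatter). Both steps are beyond the scatter, and both pair a higher number with the open chain. Compound 4 also has an open chain, so a similar move towards higher numbers is expected, though no such branched chain has been measured yet. The expected change is a 2.3-fold higher number from compound 3 to compound 4 (0.35 log units; beyond the scatter), and the assay may report only a limit. For compound 4 the estimated value is 70000 nM, with an expected range of 30000 nM to 100000 nM.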

Compound 4, half-maximal cytotoxic concentration: 43000 nM
For compound 4 the middle estimate is 1.6-fold (0.21 log units) above the measured one; measured number inside the range.
By their numbers in this assay, from the lowest: compounds 3, 1 and 4 (each within the scatter of the next). At a limit, above all of these: compound 2.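

In this assay, an open chain on the amide-type nitrogen does not by itself set a compound apart from the aryl compounds, and compound 4 goes against the link that the ethyl of compound 2 had suggested: a 1.4-fold higher number from compound 3 to compound 4 (0.14 log units; within the scatter), and a 1.1-fold higher number from compound 1 to compound 4 (0.04 log units; within the scatter). The step that lies beyond the scatter falls between the two open chains, with 1-methylethenyl in place of methyl on a saturated chain carbon bound to an amide-type nitrogen: an at least 2.3-fold lower number from compound 2 to compound 4 (0.36 log units; beyond the scatter). Compound 2 remains the only compound at a limit: the limit of > 100000 nM in this assay, at which 1 of the 4 values shown sits.

The compounds shown leave open whether the double bond or the extra carbons of 2-methylprop-2-en-1-yl go with this step. They also leave open where a propyl chain, or a chain ending in an amine, would stand.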